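Epimer of the unsubstituted piperazine in a calcium-flux assay

This account rests on a few compounds, and the source may have more. Where it says the series, first, only, none or still open, it means among the compounds named here.

Compound 3, `NCCCCN(C[C@H]1CNCCN1)[C@H]1CCCc2cccnc21`, gives the highest number of the three measured compounds in a functional assay on Chem-1 cells for antagonist activity at C-X-C chemokine receptor type 4 (Homo sapiens), read by calcium flux (on this read-out lower numbers stand for stronger inhibition and higher numbers for weaker inhibition), at 255 nM. Compound 2, `NCCCCN(C[C@H]1CN(S(=O)(=O)c2ccc(Cl)cc2)CCN1)[C@H]1CCCc2cccnc21`, gives 2 nM, and compound 1, `NCCCCN(C[C@@H]1CN(C(=O)c2ccco2)CCN1)[C@H]1CCCc2cccnc21`, gives 35 nM. Among the compounds with values here, the only measured single-point step is a 130-fold higher number from compound 2 to compound 3 (2.11 log units; beyond the scatter), which concerns the loss of the (4-chlorophenyl)sulfonyl group, not configuration.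

Compound 4, `NCCCCN(C[C@@H]1CNCCN1)[C@H]1CCCc2cccnc21`, differs from compound 3 only in that (the two compounds have the same atoms and bonds and differ only in configuration as drawn: 1 of 2 stereo elements differ; a stereocentre at a saturated ring carbon is drawn R in compound 3 and S in compound 4). Within the data shown here, no measured step isolates a change of configuration alone; compounds 1 and 2 carry opposite drawings at that carbon but also differ in the group on the ring nitrogen, so their values cannot be read as a stereochemical step. Among the measured compounds shown here, the bearing of the one known step is therefore indirect, and the size of any shift is uncertain. Compound 4 is expected to show a modest step of a 2.0-fold higher number from compound 3 to compound 4 (0.29 log units; within the scatter) in this assay, and its estimated value is 500 nM, within a range from 100 nM to 2500 nM.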

Compound 4, half-maximal inhibitory concentration: 1200 nM
The estimate for compound 4 lay 2.4-fold (0.38 log units) below the measured number; low and high end bracket the measured number.
By their numbers in this assay, from the lowest: compound 2; then compound 1; then compound 3; then compound 4.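

In this assay, within the data shown here, the stereocentre at the saturated ring carbon now has a measured effect of its own, with a 4.7-fold higher number from compound 3 to compound 4 (0.67 log units; beyond the scatter) as the first step at this position to isolate configuration. The step can be assigned to that stereocentre alone because of how the pair is related: the fact that compounds 3 and 4 differ only in the configuration as drawn. The S drawing also shows that the group on the ring nitrogen matters there, with a 34-fold higher number from compound 1 to compound 4 (1.54 log units; beyond the scatter) on replacing (furan-2-yl)carbonyl with hydrogen, a large step like a 130-fold higher number from compound 2 to compound 3 (2.11 log units; beyond the scatter) in the R drawing.

The compounds shown leave open whether the stereocentre keeps this effect when the ring nitrogen carries (furan-2-yl)carbonyl or (4-chlorophenyl)sulfonyl. They also leave open how an acetyl or benzyl group on that nitrogen would compare in either drawing.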